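The source may report more compounds than this note shows. Statements on the series, on what has been measured and on what is new or still open speak of the compounds shown alone.

Compound 2 `CN(CCCN1CCCCC1)c1ccc(C(=O)N2CCc3ccc(OS(N)(=O)=O)cc3C2)cc1` gives 17.4% in an assay on HEK293 cells for inhibition of Steryl-sulfatase (Homo sapiens), tested at 0.1 uM (a lower number here means a weaker effect, a higher number a stronger effect of the compound at the concentration tested), the lower of the two measured numbers. For the measured compounds named here, compound 1 `CC(C)CCN(CCC(C)C)c1ccc(C(=O)N2CCc3ccc(OS(N)(=O)=O)cc3C2)cc1` gives 47% in this assay, and the only measured step, a number 29.6 percentage points lower from compound 1 to compound 2 (beyond the scatter), runs the other way from the change now considered. Compound 3 `CCN(Cc1cccc(Br)c1)c1ccc(C(=O)N2CCc3ccc(OS(N)(=O)=O)cc3C2)cc1` differs from compound 2 in one place: (3-bromobenzyl)(ethyl)amino in place of methyl(3-(piperidin-1-yl)propyl)amino on an aromatic carbon. Since that one step lowered the number when a piperidin-1-yl chain entered, its departure here is expected to raise the number again, by a number 22.6 percentage points higher from compound 2 to compound 3 (beyond the scatter) from compound 2 to compound 3. Compound 3 is therefore estimated at 40%, within a range of 15% to 65%.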

Compound 3, a percentage reported as inhibition, at one concentration (the size of the read-out at that concentration, not a potency) in the Steryl-sulfatase assay: 80.2%
The estimate for compound 3 lay 40.2 percentage points below the measured number; the measured number lies above the stated range.
By their numbers in the Steryl-sulfatase assay, from the lowest: compound 2; then compound 1; then compound 3.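

In the Steryl-sulfatase assay, compound 3 gives 80.2%; the change at this aromatic carbon gives a number 62.8 percentage points higher from compound 2 to compound 3 (beyond the scatter), and a second comparison gives a number 33.2 percentage points higher from compound 1 to compound 3 (beyond the scatter), so (3-bromobenzyl)(ethyl)amino surpasses both amino groups seen earlier. For the compounds shown here, in a physicochemical assay for lipophilicity (on this read-out lower numbers stand for lower lipophilicity and higher numbers for higher lipophilicity), compound 2 gives 1.93 and compound 3 gives 1.93; the same change gives no change at the digits printed from compound 2 to compound 3 (within the scatter), so the large step in inhibition occurs with no accompanying step in lipophilicity.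

The compounds shown do not separate the contribution of the bromine from that of the aromatic ring, which an unsubstituted benzyl or a 3-chlorobenzyl group could address. No available evidence gives a reason for the step.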